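Two Chlorines for Two Fluorines on the Ring Amine

The source may hold more compounds than are shown below. What is called first, only, known or untested is meant among the compounds shown, and "the series" means these compounds.

Compound 1 `COc1ccc(N2CCN(Cc3csc(N)c3C(=O)c3ccc(Cl)cc3)CC2)cc1`: -1.2%
Compound 2 `Nc1scc(CN2CCN(C3CCCCCC3)CC2)c1C(=O)c1ccc(Cl)cc1`: 2.9%
Compound 3 `Nc1scc(CN2CCN(c3cc(F)cc(F)c3)CC2)c1C(=O)c1ccc(Cl)cc1`: -13%

These three compounds were tested in a functional assay on CHO cells with adenosine receptor A1 (Homo sapiens) as the target, read by cAMP accumulation and immunoassay, with a stated time of 6 min, tested at 0.01 uM; a lower number here means a stronger effect, a higher number a weaker effect of the compound at the concentration tested. Compound 3 gives the lowest of the three numbers, with compound 1 closest and compound 2 furthest. Compound 4 `Nc1scc(CN2CCN(c3ccc(Cl)c(Cl)c3)CC2)c1C(=O)c1ccc(Cl)cc1` differs from compound 3 only in one place: 3,4-dichlorophenyl in place of 3,5-difluorophenyl on an amine nitrogen in a ring. The two measured steps that bear on this change are both swaps of the group on the same ring nitrogen: a number 11.8 percentage points lower from compound 1 to compound 3 (beyond the scatter) and a number 15.9 percentage points lower from compound 2 to compound 3 (beyond the scatter). Both were modest, and neither involves the entering group, so the expected step in this assay is small, with a slight lean toward the other two compounds: a number 5 percentage points higher from compound 3 to compound 4 (within the scatter) is estimated. Compound 4 is therefore expected to give about -8%, within -22% to 6%.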

Compound 4, a percentage reported as activity, at one concentration (the size of the read-out at that concentration, not a potency): -1.2%
Estimate against measurement, compound 4: 6.8 percentage points below, within the range that was stated.
By their numbers in this assay, from the lowest: compound 3; then compounds 1, 4 and 2 (each within the scatter of the next).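

Replacing 3,5-difluorophenyl with 3,4-dichlorophenyl in this assay gives a number 11.8 percentage points higher from compound 3 to compound 4 (beyond the scatter) and so shows that this position can tell two dihalogenated phenyl groups apart. The new group also sits level with the earlier ones, with a number 4.1 percentage points lower from compound 2 to compound 4 (within the scatter) and no change at the digits printed from compound 1 to compound 4 (within the scatter) leaving compound 3 alone apart from the other three. No measured evidence explains this difference.

From the compounds shown here alone, compound 3 and compound 4 differ in both halogen and substitution pattern, so it stays open which of these matters. Going by these compounds, the effect of an amine or a carboxylic acid on this phenyl ring also remains open.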